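A few compounds are considered here, and "the series" means these few. Any claim that something is new, unique, unknown or untested is made for them only; others in the source may bear on it.

Working notes on the series. Of the compounds shown here, three sharing one core have been measured in a functional assay, read by spectrophotometry, with a stated time of 1 h; on this read-out lower numbers stand for stronger inhibition and higher numbers for weaker inhibition. Compound 1 `Cc1ccc2[nH]c(=O)c(/C=N/c3ccc(C(=O)O)cc3)cc2c1` gives "not active" (no number reported) in this assay. Compound 2 `O=c1[nH]c2ccccc2cc1/C=N/c1ccccc1O` gives 1660000 nM, the lowest of the two numbers on hand. Compound 3 `O=c1[nH]c2ccccc2cc1/C=N/Cc1ccccc1` gives 3140000 nM; its number and that of compound 2 sit within the usual scatter of each other, so no order between them is claimed. Among the compounds with values here, no single-change step between measured compounds is available.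

Compound 4 `Cc1ccc2[nH]c(=O)c(/C=N/c3ccccc3O)cc2c1` is the next entry for this assay. Relative to compound 2 the change is methyl in place of hydrogen on an aromatic carbon. Within the data shown here, with no measured step of this kind, the expected step from compound 2 to compound 4 is a 1.2-fold higher number from compound 2 to compound 4 (0.08 log units; within the scatter), that is, none beyond the scatter. For compound 4 the estimate is 2000000 nM, with a range from 700000 nM to 6000000 nM.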

Compound 4, half-maximal inhibitory concentration: 1350000 nM
Compound 4: middle estimate off by 1.5-fold (0.17 log units), on the high side; low and high end bracket the measured number.
By their numbers in this assay, from the lowest: compounds 4, 2 and 3 (each within the scatter of the next, the first and the last beyond it).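

Methyl in place of hydrogen on an aromatic carbon, meta to a fused ring and para to a fused ring, gives a 1.2-fold lower number from compound 2 to compound 4 (0.09 log units; within the scatter) in this assay and so gives the series its first single-change step, with no change that can be told from the scatter. No supporting measurement bears on this result.

The compounds shown leave open whether a different group at this position, such as an amine, a methoxy group or a longer chain, would give a step beyond the scatter. They also leave open whether methyl gives the same step when the hydroxyl-bearing ring is replaced.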